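Piperidine amide to benzylamine switch in oxazole ketone series

A few compounds are considered here, and "the series" means these few. Any claim that something is new, unique, unknown or untested is made for them only; others in the source may bear on it.

Measured compounds:
compound 1 `O=C(CCCC1CCN(C(=O)CCc2ccccc2)CC1)c1ncco1`: 22 nM
compound 2 `O=C(CCCC1CCN(C(=O)CC2CCCCC2)CC1)c1ncco1`: 100 nM
compound 3 `CC(C)C(=O)N1CCC(CCCC(=O)c2ncco2)CC1`: 250 nM

All three numbers come from an assay on isolated protein for inhibition of Fatty-acid amide hydrolase 1 (Homo sapiens); a higher number here means a weaker inhibitor, a lower number a stronger inhibitor. Compound 3 stands highest of the three: the step of a 2.5-fold higher number from compound 2 to compound 3 (0.40 log units; beyond the scatter) is beyond the scatter, and the step of an 11-fold higher number from compound 1 to compound 3 (1.06 log units; beyond the scatter) is larger still. Within the amide series the step of a 4.5-fold higher number from compound 1 to compound 2 (0.66 log units; beyond the scatter) shows that the compound carrying the aromatic ring gives the lower number.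

Compound 4 `O=C(CCCC1CCN(Cc2ccccc2Br)CC1)c1ncco1` is not yet measured. The change from compound 3 is 2-bromobenzyl in place of isopropylcarbonyl on an amine nitrogen in a ring. Within the data shown here, two measured steps bear on it loosely: an 11-fold higher number from compound 1 to compound 3 (1.06 log units; beyond the scatter) and a 2.5-fold higher number from compound 2 to compound 3 (0.40 log units; beyond the scatter) both run from a larger group to the isopropyl and both raise the number, so the reverse direction, a larger group entering, points toward a lower number. Among the measured compounds shown here, none of the measured steps removes the carbonyl itself, so that part of the change is not covered by anything seen here, and the expectation is held wide. The step of a 2.1-fold lower number from compound 3 to compound 4 (0.32 log units; beyond the scatter) is therefore expected to be modest and toward a lower number. For compound 4 in this assay the estimate is 120 nM, with a range from 30 nM to 600 nM.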

Compound 4, half-maximal inhibitory concentration: 315 nM
Compound 4: middle estimate off by 2.6-fold (0.42 log units), on the low side; measured number inside the range.
By their numbers in this assay, from the lowest: compound 1; then compound 2; then compounds 3 and 4 (each within the scatter of the next).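

In this assay, a 1.3-fold higher number from compound 3 to compound 4 (0.10 log units; within the scatter) shows that, on the amine nitrogen in the ring, 2-bromobenzyl and isopropylcarbonyl cannot be told apart, even though the change removes the carbonyl and brings in an aromatic ring. The earlier steps shown here, an 11-fold higher number from compound 1 to compound 3 (1.06 log units; beyond the scatter) and a 2.5-fold higher number from compound 2 to compound 3 (0.40 log units; beyond the scatter), all kept the carbonyl and linked a larger group on it with a lower number than isopropyl gives; compound 4 goes against any wider reading of that link, since a larger group on this nitrogen without the carbonyl gives no such separation from compound 3. The loss of the carbonyl and the entry of the 2-bromobenzyl happen in a single change, so their separate contributions cannot be read, and nothing measured here accounts for the result.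

The compounds shown leave open whether the bromine matters, which a plain benzyl on the same nitrogen would address. They also leave open what the same aromatic ring does with the carbonyl kept, as in a 2-bromobenzoyl group, and how a phenethyl group attached directly to the nitrogen would compare with the amide of compound 1.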